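Repeating a Thiophen-2-yl Swap on a Second Core

This account rests on a few compounds, and the source may have more. Where it says the series, first, only, none or still open, it means among the compounds named here.

Compound 1 `CN1CCN(c2ccc(Nc3ncc(/N=C/c4cccs4)c(NC4CCCC4)n3)cc2)CC1` and compound 2 `CN1CCN(c2ccc(Nc3ncc(/N=C/c4ccc(C(F)(F)F)cc4)c(NC4CCCC4)n3)cc2)CC1` share one core, while compound 3 `CC(C)Nc1nc(Nc2ccc(S(N)(=O)=O)cc2)ncc1/N=C/c1cccs1` is built on another; the difference between the two cores is not broken down here. In a functional assay on HeLa cells (Homo sapiens) for antiproliferative activity, read by MTT assay (a lower number here means a stronger inhibitor, a higher number a weaker inhibitor), compound 1 gives 25700 nM. For compound 2 in this assay only a limit is recorded, > 100000 nM. The change 4-(trifluoromethyl)phenyl in place of thiophen-2-yl on a carbon with a double bond to nitrogen therefore produced an at least 3.8-fold higher number from compound 1 to compound 2 (0.59 log units; beyond the scatter). For compound 3 in this assay the same limit is recorded, > 100000 nM. Compound 4 `CC(C)Nc1nc(Nc2ccc(S(N)(=O)=O)cc2)ncc1/N=C/c1ccc(C(F)(F)F)cc1` arises from compound 3 by the same change, (4-(trifluoromethyl)phenyl in place of thiophen-2-yl on a carbon with a double bond to nitrogen), at a place described in identical words. Because the limit of > 100000 nM in this assay, at which 2 of the 3 values shown sit, already holds compound 3, and because the earlier swap gave an at least 3.8-fold higher number from compound 1 to compound 2 (0.59 log units; beyond the scatter), compound 4 is expected to remain at that limit, an expected step that the limit leaves unreadable from compound 3 to compound 4. The estimate for compound 4 is 200000 nM, expected between 80000 nM and 600000 nM.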

Compound 4, half-maximal inhibitory concentration: > 100000 nM
Compound 4: no number, only a limit; the forecaster's own chance of this, stated with the estimate: 90%; the middle value lies beyond the limit too.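

Compound 3 and compound 4 each carry only a limit in this assay, and the step between them cannot be read. The compounds shown leave open whether this swap changes activity at all on the core of compound 3.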